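The compounds below may be only part of what the source reports. "The series", "measured", "known", "first", "only" and "open" are said of these compounds alone.

Measured compounds: compound 1 `COc1cc(-c2nn(-c3cccc(NC(=O)c4cccc(C(F)(F)F)c4)c3)cc2-c2ccncc2)ccc1Cl`, compound 2 `O=C(Nc1cccc(-n2cc(-c3ccncc3)c(-c3ccc(Cl)c(O)c3)n2)c1)Nc1cc(C(F)(F)F)cc(C(F)(F)F)c1`, compound 3 `COc1cc(-c2nn(-c3cccc(NC(=O)Nc4cccc(C(F)(F)F)c4)c3)cc2-c2ccncc2)ccc1Cl`.

In a functional assay on SK-MEL-2 cells (Homo sapiens) for inhibition, read by sulforhodamine B assay, with a stated time of 48 h (a lower number here means that less compound is tolerated, a higher number that more compound is tolerated), compound 1 gives > 50000 nM, which is a limit of the assay (the limit of > 50000 nM in this assay, at which 1 of the 3 values shown sits). Compound 2 gives 14100 nM and compound 3 gives 3960 nM. Compound 3 thus has the lowest of the two numbers, with compound 2 nearest and higher. The unmeasured compound 4 `COc1cc(-c2nn(-c3cccc(NC(=O)Nc4cc(C(F)(F)F)cc(C(F)(F)F)c4)c3)cc2-c2ccncc2)ccc1Cl` differs from compound 3 by trifluoromethyl in place of hydrogen on an aromatic carbon. Going by the values given here, the one measured step, an at least 12-fold lower number from compound 1 to compound 3 (1.10 log units; beyond the scatter), changes the carbonyl substituent rather than a ring position, so it does not bear directly on this change. Compound 2, which also carries two trifluoromethyl groups on its urea, shows a higher number than compound 3. The expected step for compound 4 is a 1.4-fold higher number from compound 3 to compound 4 (0.14 log units; within the scatter), a small rise within the scatter. Compound 4 is estimated at 5500 nM, between 1500 nM and 18000 nM.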

Compound 4, concentration lethal to 50% of the cells: 3710 nM
Compound 4: middle estimate off by 1.5-fold (0.17 log units), on the high side; the measured number falls inside the stated range.
By their numbers in this assay, from the lowest: compounds 4 and 3 (each within the scatter of the next); then compound 2. At a limit, above all of these: compound 1.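

In this assay, trifluoromethyl in place of hydrogen at this ring position makes no readable difference: a 1.1-fold lower number from compound 3 to compound 4 (0.03 log units; within the scatter). With both trifluoromethyl groups present, methyl in place of hydrogen on the oxygen is a change that can be read: a 3.8-fold lower number from compound 2 to compound 4 (0.58 log units; beyond the scatter). No measurement shown gives a reason for either step. The compounds shown leave open whether a nitrile or an amine at this ring position would shift the number. They also leave open what a longer chain on the oxygen would do.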